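A Chloro Swap Carried Over to a Second Core

The source may report more compounds than this note shows. Statements on the series, on what has been measured and on what is new or still open speak of the compounds shown alone.

Measured compounds:
compound 1, `COc1ccc(OC)c(-c2cc(-c3ccccc3)nn2-c2ccc(S(=O)(=O)NC(C)=O)cc2)c1`, gives 53400 nM
compound 2, `COc1ccc(OC)c(-c2cc(-c3ccc(Cl)cc3)nn2-c2ccc(S(=O)(=O)NC(C)=O)cc2)c1`, gives 50100 nM
compound 3, `NS(=O)(=O)c1ccc(-n2nc(-c3ccccc3)cc2-c2cc(O)ccc2O)cc1`, gives 100000 nM

The three measured compounds were tested in a functional assay on cells (Leukemia cell, Homo sapiens) for cytotoxicity, read by sulforhodamine B assay, with a stated time of 48 h; on this read-out higher numbers stand for weaker inhibition of growth and lower numbers for stronger inhibition of growth. Compound 1 gives 53400 nM in this assay, and compound 2 gives 50100 nM. The two differ by one change, (chloro in place of hydrogen on an aromatic carbon), and the step of a 1.1-fold lower number from compound 1 to compound 2 (0.03 log units; within the scatter) shows that the change left the read-out essentially where it was. Compound 3 carries a different core, and the difference between the core of compound 1 and the core of compound 3 is not broken down here; in this assay compound 3 gives 100000 nM, which sits within the scatter of both compound 1 and compound 2.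

The unmeasured compound 4, `NS(=O)(=O)c1ccc(-n2nc(-c3ccc(Cl)cc3)cc2-c2cc(O)ccc2O)cc1`, is compound 3 with the same change applied: chloro in place of hydrogen on an aromatic carbon. The place of the change is described in the same words for both pairs, so this is the same change, now set on the core of compound 3 rather than the core of compound 1.

Because the step of a 1.1-fold lower number from compound 1 to compound 2 (0.03 log units; within the scatter) stayed within the scatter, compound 4 is expected to stay close to compound 3, and the estimated step is a 1.1-fold lower number from compound 3 to compound 4 (0.05 log units; within the scatter). Among the compounds with values here, compound 4 is therefore estimated at 90000 nM, with a range from 40000 nM to 200000 nM, resting on the single measured step from compound 1 to compound 2 and on the value of compound 3.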

Compound 4, concentration for total growth inhibition: 61400 nM
For compound 4 the middle estimate is 1.5-fold (0.17 log units) above the measured one; the measured number falls inside the stated range.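

On the core of compound 3, the chloro change gives a 1.6-fold lower number from compound 3 to compound 4 (0.21 log units; within the scatter) in this assay, so phenyl to 4-chlorophenyl again leaves the read-out within the scatter. Set beside the step on the core of compound 1, the new step shows that the change behaves alike on both cores, with no gap between the two steps that exceeds what repeated measurements allow: the same change on two cores in this assay, a 1.1-fold lower number (0.03 log units; within the scatter) from compound 1 to compound 2 and a 1.6-fold lower number (0.21 log units; within the scatter) from compound 3 to compound 4, 1.5-fold (0.18 log units) apart, within the scatter of two such steps. Within the data shown here, this shows only that the change stays within the scatter on each of these two cores; since neither step can be told from no change, the pairs do not show that chloro has any effect on growth inhibition to carry over, and two pairs do not show that the same would hold on any further core.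

The compounds shown leave open whether an amine, a carboxylic acid or a longer chain in place of the chloro, on the same six-membered aromatic ring, would move the read-out beyond the scatter on either core. They also leave open which of the features that separate the core of compound 1 from the core of compound 3 matters in this assay, if any does.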